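The compounds below may be only part of what the source reports. "The series", "measured", "known", "first", "only" and "open" are said of these compounds alone.

Working notes on the series.

Compound 1 `COc1ccc(-c2cc(C(=O)Nc3nc4ccc(Cl)cc4s3)nc3cc(-c4ccccc4)nn23)cc1` and compound 2 `COc1ccc(-c2cc(C(=O)Nc3nc4ccc(F)cc4s3)nc3cc(-c4ccccc4)nn23)cc1` share one core and differ only in the halogen on the fused ring. In a functional assay on HeLa cells (Homo sapiens) for cytotoxicity, read by MTT assay, with a stated time of 48 h (a higher number here means a weaker inhibitor, a lower number a stronger inhibitor), compound 1 gives 5880 nM. In this assay compound 2 gives 41700 nM. Among the compounds with values here, the single measured step, a 7.1-fold higher number from compound 1 to compound 2 (0.85 log units; beyond the scatter), is the only comparison so far, and on these two numbers compound 2 stands at the higher, weaker end of the pair.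

Compound 3 `COc1ccc(-c2cc(C(=O)Nc3nc4ccccc4s3)nc3cc(-c4ccccc4)nn23)cc1` is the next member, not yet measured. Against compound 2 the change is hydrogen in place of fluoro on an aromatic carbon. Within the data shown here, no measured step bears directly on taking the halogen away altogether; the one step available, from chloro to fluoro, went to a higher number, so the direction of a further move to hydrogen is not settled by the data. For compound 3 the step from the fluoro parent is expected to be small, a 1.1-fold higher number from compound 2 to compound 3 (0.03 log units; within the scatter), with a wide range. The estimate for compound 3 in this assay is 45000 nM, expected to fall between 12000 nM and 170000 nM.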

Compound 3, half-maximal inhibitory concentration: 4670 nM
Compound 3: the middle estimate sits 9.6-fold (0.98 log units) above what was measured; measured number outside the range, below it.
By their numbers in this assay, from the lowest: compounds 3 and 1 (each within the scatter of the next); then compound 2.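

Hydrogen at this position, in place of fluoro on the benzothiazole's aromatic carbon, gives in this assay a clear move back, with an 8.9-fold lower number from compound 2 to compound 3 (0.95 log units; beyond the scatter) and so the fluoro step is not a small change around an inactive parent. Compound 2 is the weakest of the three, and the unsubstituted ring does not extend the direction seen in going from chloro to fluoro, since the comparison with chloro reads a 1.3-fold lower number from compound 1 to compound 3 (0.10 log units; within the scatter) and leaves those two compounds level in this assay. Among the three compounds, then, the position does not respond to the presence of a halogen as such. Chloro and hydrogen cannot be told apart and only fluoro stands away from them. Nothing at hand gives a reason for that.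

Going by these compounds, whether the loss is peculiar to the 6-fluoro-1,3-benzothiazol-2-yl compound or also appears with other groups at this position, such as bromo, a nitrile or an amine, remains open. Also open, on these data alone, is whether the same pattern holds when the rest of the shared core is changed, as all three compounds carry it unaltered.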